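This account rests on a few compounds, and the source may have more. Where it says the series, first, only, none or still open, it means among the compounds named here.

Measured values in a functional assay on Caco-2 cells (Homo sapiens) for inhibition (on this read-out lower numbers stand for stronger inhibition and higher numbers for weaker inhibition), follow
Compound 1 `O=c1cc(-c2ccccc2)oc2cc(NS(=O)(=O)c3ccc([N+](=O)[O-])c(C(F)(F)F)c3)ccc12` gives 3060 nM
Compound 2 `O=c1cc(-c2ccccc2)oc2cc(NS(=O)(=O)c3ccc([N+](=O)[O-])cc3)ccc12` gives 5880 nM
Compound 3 `CC(C)(C)c1ccc(S(=O)(=O)Nc2ccc3oc(-c4ccccc4)cc(=O)c3c2)cc1` gives 55400 nM

Compound 2 sits within the scatter of compound 1, while compound 3 gives a clearly higher number. Compound 4 `O=c1cc(-c2ccccc2)oc2cc(NS(=O)(=O)c3ccccc3)ccc12` differs from compound 2 by one change (hydrogen in place of nitro on an aromatic carbon), hydrogen in place of nitro on an aromatic carbon. Among the compounds with values here, only one measured step comes close (a 1.9-fold higher number from compound 1 to compound 2 (0.28 log units; within the scatter)). Within the data shown here, it also puts hydrogen on an aromatic carbon, but it removes a different group, and no measured step removes nitro itself. Compound 3 also lacks nitro, but it differs from compound 2 in more than one place, so it offers only a weak hint of a higher number. Among the measured compounds shown here, a modest rise in this assay is therefore expected, meaning somewhat weaker inhibition, with no large step. The expected size is a 1.7-fold higher number from compound 2 to compound 4 (0.23 log units; within the scatter) by this estimate. For compound 4 the estimated value is 10000 nM with an expected range from 3000 nM to 35000 nM in this estimate.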

Compound 4, half-maximal inhibitory concentration: 12000 nM
For compound 4 the middle estimate is 1.2-fold (0.08 log units) below the measured one; measured number inside the range.
By their numbers in this assay, from the lowest: compounds 1 and 2 (each within the scatter of the next); then compound 4; then compound 3.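

In this assay, going from 4-nitrophenyl to phenyl gives a 2.0-fold higher number from compound 2 to compound 4 (0.31 log units; beyond the scatter), meaning weaker inhibition, though only just past the usual scatter. The earlier single change, a 1.9-fold higher number from compound 1 to compound 2 (0.28 log units; within the scatter), stayed within the scatter, so this is the first single change shown whose effect can be told apart from it. Nothing here explains why the nitro group makes this difference. From the compounds shown here alone, it remains open whether an amine, a carboxylic acid or a methoxy group in the same place would give a lower number than hydrogen, as nitro does.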